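Methoxymethyl on a Second Ring Nitrogen: Expected Antiproliferative Potency

The source may hold more compounds than are shown below. What is called first, only, known or untested is meant among the compounds shown, and "the series" means these compounds.

Compound 1 `O=c1cc(CC(O)(COCc2ccccc2)COCc2ccccc2)[nH]c(=O)[nH]1` and compound 2 `COCn1c(CC(O)(COCc2ccccc2)COCc2ccccc2)cc(=O)[nH]c1=O` share a core that compound 3 `COCn1c(=O)[nH]c(CC(COCc2ccccc2)COCc2ccccc2)c(C)c1=O` carries in a methyl-bearing form; the difference between the two cores is not broken down here. In a functional assay on SW-620 cells (Homo sapiens) for antiproliferative activity, read by MTT assay, with a stated time of 72 h (on this read-out higher numbers stand for weaker inhibition and lower numbers for stronger inhibition), compound 1 gives > 100000 nM, which is a limit of the assay and not a number. Compound 2 gives > 100000 nM in this assay, again a limit. The change from compound 1 to compound 2 is methoxymethyl in place of hydrogen on an aromatic nitrogen, and the step it made is a step that the two limits leave unreadable from compound 1 to compound 2, because the limit of > 100000 nM in this assay, at which 2 of the 3 values shown sit, leaves its size unreadable. Among the compounds with values here, compound 3 gives 25600 nM in this assay, the only number among the three.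

Compound 4 `COCn1c(CC(COCc2ccccc2)COCc2ccccc2)c(C)c(=O)n(COC)c1=O` is the not yet measured partner of compound 3, differing by methoxymethyl in place of hydrogen on an aromatic nitrogen. Within the data shown here, this is the same kind of change as the one from compound 1 to compound 2, but here the place is meta to a methoxymethyl group (3 heavy atoms) and meta to a methyl group (1 heavy atom). Since the earlier step is unreadable, the step from compound 3 to compound 4 is expected to be small, a 1.2-fold higher number from compound 3 to compound 4 (0.07 log units; within the scatter). Compound 4 is therefore estimated at 30000 nM, with a likely range from 8000 nM to 120000 nM.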

Compound 4, half-maximal inhibitory concentration: 500 nM
Estimate against measurement, compound 4: 60-fold (1.78 log units) above, and the stated range ends above it.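

In this assay, methoxymethyl in place of hydrogen on an aromatic nitrogen gave a 51-fold lower number from compound 3 to compound 4 (1.71 log units; beyond the scatter), which shows that on the core of compound 3 this change, at the place meta to a methoxymethyl group and meta to a methyl group, goes with a large gain in antiproliferative potency. This single pair does not show that the gain carries from one core to another in this series. The same change on the core of compound 1 cannot be read, and the two steps cannot be compared, because the values of compound 1 and compound 2 are limits of the assay and not numbers: the limit of > 100000 nM in this assay, at which 2 of the 4 values shown sit.

The compounds shown leave open whether the gain is specific to methoxymethyl or would also appear with an ethyl group, a longer ether chain or a chain ending in an amine at the same nitrogen. They also leave open how much the methyl group on the core of compound 3 contributes to the size of the step.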